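A few compounds are considered here, and "the series" means these few. Any claim that something is new, unique, unknown or untested is made for them only; others in the source may bear on it.

Measured so far in a functional assay on HCT-116 cells (Homo sapiens) for cytotoxicity, read by MTT assay, with a stated time of 48 h; a higher number here means a weaker inhibitor, a lower number a stronger inhibitor:
compound 1 `O=C(CSCc1nc2cc([N+](=O)[O-])ccc2[nH]1)c1ccc(Br)cc1`, 1780 nM
compound 2 `CCOC(=O)CSCc1nc2cc([N+](=O)[O-])ccc2[nH]1`, > 100000 nM
compound 3 `NC(=O)CSCc1nc2cc([N+](=O)[O-])ccc2[nH]1`, 17200 nM

The value of compound 2 is a limit of this assay, not a number (the limit of > 100000 nM in this assay, at which 1 of the 3 values shown sits). Among the numbers, compound 3 gives the highest; its nearest neighbour is compound 1, with a 9.7-fold higher number from compound 1 to compound 3 (0.99 log units; beyond the scatter). Compound 2 to compound 3 shows an at least 5.8-fold lower number from compound 2 to compound 3 (0.76 log units; beyond the scatter).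

Compound 4 `O=C(CSCc1nc2cc([N+](=O)[O-])ccc2[nH]1)N/N=C/c1ccc(Cl)cc1` differs from compound 3 by a group of 9 heavy atoms (7 carbon, 1 nitrogen, 1 chlorine; one six-membered aromatic ring of carbon only) in place of a hydrogen atom, on an amide-type nitrogen. The step from compound 1 to compound 3 removed an aromatic ring from the carbonyl carbon and weakened the inhibitor; compound 4 brings an aromatic ring back, on the amide-type nitrogen. A moderate drop in the number is therefore expected, a 4.9-fold lower number from compound 3 to compound 4 (0.69 log units; beyond the scatter), giving an estimate for compound 4 of 3500 nM, between 800 nM and 15000 nM.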

Compound 4, half-maximal inhibitory concentration: 15300 nM
Compound 4: middle estimate off by 4.4-fold (0.64 log units), on the low side; the measured number lies above the stated range.
By their numbers in this assay, from the lowest: compound 1; then compounds 4 and 3 (each within the scatter of the next). At a limit, above all of these: compound 2.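

On the amide-type nitrogen, a group of 9 heavy atoms with a six-membered aromatic ring can replace a hydrogen atom without a real shift in this assay, with a 1.1-fold lower number from compound 3 to compound 4 (0.05 log units; within the scatter). An aromatic ring at this position is therefore not enough by itself to lower the number. Nothing measured here gives a reason for this result.

As far as these compounds go, whether a methyl group or an aminoethyl chain on this nitrogen would move the number stays open, as does the effect of replacing the chlorine with a methoxy group.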